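The source may report more compounds than this note shows. Statements on the series, on what has been measured and on what is new or still open speak of the compounds shown alone.

Working notes on the series. In a functional assay on OCI-Ly3 cells (Homo sapiens) for inhibition, read by CellTiter-Glo, with stated times of 48 h and 96 h (a higher number here means a weaker inhibitor of growth, a lower number a stronger inhibitor of growth), compound 1 `CC(C)[C@H](NC(=O)c1ccccc1Br)C(=O)N1CCC[C@H]1C(=O)N[C@@H](CCCNC(=N)N)C(=O)CF` gives 4240 nM and compound 2 `COc1ccc(C(=O)N[C@H](C(=O)N2CCC[C@H]2C(=O)N[C@@H](CCCNC(=N)N)C(=O)CF)C(C)C)cc1` gives 1670 nM. Among the measured compounds shown here, compound 2 therefore holds the lower of the two numbers so far. The next entry is compound 3 `CC(C)c1ccc(C(=O)N[C@H](C(=O)N2CCC[C@H]2C(=O)N[C@@H](CCCNC(=N)N)C(=O)CF)C(C)C)cc1`, which carries isopropyl in place of methoxy on an aromatic carbon, para to a large group: isopropyl in place of methoxy on an aromatic carbon. The rest of the structure is unchanged.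

For the measured compounds named here, only one measured step bears on this change: a 2.5-fold lower number from compound 1 to compound 2 (0.40 log units; beyond the scatter). It is modest, with 4-methoxyphenyl in place of 2-bromophenyl on a carbonyl carbon. That step alters both the group and its place on the ring, so it offers a rough size and no direction for the present swap. Going by the values given here, no measured compound carries isopropyl. A step no larger than that one is expected in this assay, most likely none beyond the scatter, with neither direction favoured. The expected change is a 1.1-fold higher number from compound 2 to compound 3 (0.03 log units; within the scatter). For compound 3 the estimated value is 1800 nM, with an expected range from 700 nM to 4500 nM.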

Compound 3, concentration for 50% growth inhibition: 270 nM
For compound 3 the middle estimate is 6.7-fold (0.82 log units) above the measured one; the measured number lies below the stated range.
By their numbers in this assay, from the lowest: compound 3; then compound 2; then compound 1.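

In this assay, the aromatic carbon para to a large group proves sensitive to an exchange of two small groups: isopropyl in place of methoxy gives a 6.2-fold lower number from compound 2 to compound 3 (0.79 log units; beyond the scatter) and so places compound 3 lowest of the three. Among the compounds shown here, the exchange of the whole aryl group, 4-isopropylphenyl in place of 2-bromophenyl on a carbonyl carbon, gives a 16-fold lower number from compound 1 to compound 3 (1.20 log units; beyond the scatter) and is the largest step so far. No measurement at hand speaks to what lies behind these steps.

On these data alone, it remains open whether the lower number belongs to isopropyl in particular or would also come with other carbon-only groups on this aromatic carbon, such as ethyl, cyclopropyl or tert-butyl. As far as these compounds go, it also remains open how a halogen such as chlorine, an amine or a carboxylic acid would fare at this place, and whether isopropyl would give a step of similar size with the rest of the structure changed.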